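A few compounds are considered here, and "the series" means these few. Any claim that something is new, unique, unknown or untested is made for them only; others in the source may bear on it.

Compound 3 `Cc1nc(-c2ccccc2)c(C(=O)N2CCN(c3cccc(C#N)c3)CC2)o1` gives 39.6 nM in a functional assay on HL-60 cells (Homo sapiens) for inhibition, read by MTT assay, with a stated time of 72 h; a lower number here means a stronger inhibitor, a higher number a weaker inhibitor. On the numbers shown, compound 3 sits alongside compound 1 `Cc1nc(-c2ccccc2)c(C(=O)N2CCN(c3cccc(C(N)=O)c3)CC2)o1`, which gives 71 nM, because a 1.8-fold lower number from compound 1 to compound 3 (0.25 log units; within the scatter) lies within the scatter. Compound 2 `Cc1ccc(N2CCN(C(=O)c3oc(C)nc3-c3ccccc3)CC2)cc1` reaches only a limit of this assay, > 1000 nM. Two steps show that what hangs on the phenyl ring at the far end can matter greatly: an at least 14-fold higher number from compound 1 to compound 2 (1.14 log units; beyond the scatter) and an at least 25-fold lower number from compound 2 to compound 3 (1.40 log units; beyond the scatter). Compound 4 `Cc1nc(-c2ccccc2)c(C(=O)N2CCN(c3cccc(C(F)(F)F)c3)CC2)o1` keeps that ring and alters only the group on it: trifluoromethyl in place of cyano on an aromatic carbon. The closest measured step, cyano in place of carbamoyl, stayed within the scatter, so no step beyond the scatter is expected here. Compound 4 is expected at 60 nM, between 20 nM and 200 nM, a step of a 1.5-fold higher number from compound 3 to compound 4 (0.18 log units; within the scatter).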

Compound 4, half-maximal inhibitory concentration: 153 nM
For compound 4 the middle estimate is 2.6-fold (0.41 log units) below the measured one; the measured number falls inside the stated range.
By their numbers in this assay, from the lowest: compounds 3 and 1 (each within the scatter of the next); then compound 4. At a limit, above all of these: compound 2.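

Swapping the group at this position now makes a real difference: trifluoromethyl gives a 3.9-fold higher number from compound 3 to compound 4 (0.59 log units; beyond the scatter) and a 2.2-fold higher number from compound 1 to compound 4 (0.33 log units; beyond the scatter), whereas the nitrile and carbamoyl compounds stayed within the scatter of each other. Compound 4 still keeps a clear margin, with an at least 6.5-fold lower number from compound 2 to compound 4 (0.81 log units; beyond the scatter). That step is only a bound, because compound 2 stands at a limit: the limit of > 1000 nM in this assay, at which 1 of the 4 values shown sits.

As far as these compounds go, whether an amine or a carboxylic acid on this aromatic carbon would match compound 3 stays open. The numbers also give no reason for the gap between nitrile and trifluoromethyl.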